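Ethyl on the carboxymethyl chain of compound 2

The compounds below may be only part of what the source reports. "The series", "measured", "known", "first", "only" and "open" are said of these compounds alone.

In a physicochemical assay for lipophilicity, at pH 7.4 (a higher number here means a more lipophilic compound, a lower number a more polar compound), compound 1 (`O=C(O)Cn1nc(Cc2cn3cc(OCC4CC4)c(Cl)cc3n2)c2ccccc2c1=O`) gives 2.27 and compound 2 (`O=C(O)Cc1nn(Cc2cn3cc(OCC4CC4)c(Cl)cc3n2)c2ccccc2c1=O`) gives 2.13 as its reading, so the two stand within the scatter of each other. Compound 3 (`CCC(C(=O)O)c1nn(Cc2cn3cc(OCC4CC4)c(Cl)cc3n2)c2ccccc2c1=O`) differs from compound 2 by ethyl in place of hydrogen on a saturated chain carbon bound to an aromatic carbon and a carbonyl carbon as ethyl in place of hydrogen on a saturated chain carbon bound to an aromatic carbon and a carbonyl carbon. Among the compounds with values here, no measured pair shows this change, so the expectation rests on the structural change alone. In this assay a rise beyond the scatter is expected, the estimated step being a number 0.67 log units higher from compound 2 to compound 3 (beyond the scatter) for this change. Compound 3 is expected at 2.8 with a range of 2.4 to 3.2 on this reasoning.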

Compound 3, distribution coefficient: 2.71
The estimate for compound 3 lay 0.09 log units above the measured number; the range from low to high includes it.
By their numbers in this assay, from the lowest: compounds 2 and 1 (each within the scatter of the next); then compound 3.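

In this assay the change from carboxymethyl to 1-carboxypropyl gives a number 0.58 log units higher from compound 2 to compound 3 (beyond the scatter) as the first step read at this saturated chain carbon. The reading at this position therefore responds to ethyl in place of hydrogen, although this rests on a single pair. No available measurement bears on the origin of this step.

Going by these compounds, whether methyl or a longer chain such as propyl on the same carbon gives a step of similar size remains open. Also open, on these data alone, is whether ethyl gives the same step when an amide replaces the carboxylic acid.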